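The source may hold more compounds than are shown below. What is called first, only, known or untested is meant among the compounds shown, and "the series" means these compounds.

Measured compounds:

Compound 1 `CC[C@H](C)[C@H](NC(=O)[C@H](CC(=O)O)NC(=O)CCCOc1ccc(C(=N)N)cc1)C(=O)O`: 1.47
Compound 2 `CC(C)(C)CC(NC(=O)C(CC(=O)O)NC(=O)CCCOc1ccc(C(=N)N)cc1)C(=O)O`: 1.59
Compound 3 `N=C(N)c1ccc(OCCCCC(=O)NC(CC(=O)O)C(=O)NC(CO)C(=O)O)cc1`: 0.904

These three compounds share a core and were each measured in a physicochemical assay for lipophilicity; a lower number here means a more polar compound, a higher number a more lipophilic compound. In this assay compound 2 gives 1.59, the highest of the three numbers shown. Its nearest neighbour is compound 1, whose value in this assay is 1.47, a gap that lies within the scatter of repeated measurements, so the two cannot be told apart. Compound 3 gives 0.904, and that gap to compound 2 lies beyond the scatter.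

Compound 4 `Cc1ccc(OCCNC(=O)C(CC(=O)O)NC(=O)CCCOc2ccc(C(=N)N)cc2)cc1C` has not yet been measured. It differs from compound 2 in one place: 2-(3,4-dimethylphenoxy)ethyl in place of 1-carboxy-3,3-dimethylbutyl on an amide-type nitrogen. For the measured compounds named here, nothing among the measured compounds mirrors this kind of change, so no measured step can serve as a guide.

Even so, compound 4 is expected to come out more lipophilic than compound 2, with an expected step of a number 1.61 log units higher from compound 2 to compound 4 (beyond the scatter) in this assay, a step well beyond the scatter. The estimate for compound 4 in this assay is 3.2, between 2.3 and 4.1.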

Compound 4, partition coefficient: 1.43
For compound 4 the middle estimate is 1.77 log units above the measured one, outside the stated range (below it).
By their numbers in this assay, from the lowest: compound 3; then compounds 4, 1 and 2 (each within the scatter of the next).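

Replacing 1-carboxy-3,3-dimethylbutyl with 2-(3,4-dimethylphenoxy)ethyl on this amide-type nitrogen gives, in this assay, a number 0.16 log units lower from compound 2 to compound 4 (within the scatter) and so leaves the two compounds indistinguishable. This is the only step shown at this position, and it shows that a group with no ring and one hydrogen-bond donor can give way to one with a six-membered aromatic ring of carbon only and no hydrogen-bond donor without a change that rises above the scatter. The data shown offer no measurement that explains this result.

Going by these compounds, the change swaps several features at once, so the contribution of each remains unknown. A plain 2-phenoxyethyl group, or a 2-(3,4-dimethylphenoxy)ethyl group carrying a carboxylic acid, would begin to separate the effects of the two methyl groups and the acid.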